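The compounds below may be only part of what the source reports. "The series", "measured", "known", "first", "only" and "open" are said of these compounds alone.

Among the measured compounds shown here, in a physicochemical assay for lipophilicity, read by HPLC, measured as octanol-water partition, at pH 7.4 (a higher number here means a more lipophilic compound, a lower number a more polar compound), compound 2 `CNc1cc(-n2nc(C(C)C)c3c(-n4cnc(-c5cnn(C)c5)c4)ccnc32)ccc1C(N)=O` gives 3, the higher of the two numbers known so far, while compound 1 `CNc1cc(C(N)=O)ccc1-n1nc(C(C)C)c2c(-n3cnc(-c4cnn(C)c4)c3)ccnc21` gives 1.9. For the measured compounds named here, the one recorded step, a number 1.10 log units higher from compound 1 to compound 2 (beyond the scatter), moves the methylamino to another carbon rather than removing it, so it bears on the present change only indirectly. Compound 3 `CC(C)c1nn(-c2ccc(C(N)=O)cc2)c2nccc(-n3cnc(-c4cnn(C)c4)c3)c12` differs from compound 2 by hydrogen in place of methylamino on an aromatic carbon. Going by the values given here, with no measured step that removes a methylamino, a moderate fall is expected, a step of a number 0.60 log units lower from compound 2 to compound 3 (beyond the scatter), beyond the scatter. Compound 3 is therefore estimated at 2.4, with a range from 1.8 to 3.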

Compound 3, distribution coefficient: 3
Compound 3: the middle estimate sits 0.60 log units below what was measured, within the range that was stated.
By their numbers in this assay, from the lowest: compound 1; then compounds 2 and 3 (each within the scatter of the next).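

In this assay, hydrogen in place of methylamino on this aromatic carbon, ortho to a carbamoyl group, gives no change at the digits printed from compound 2 to compound 3 (within the scatter), so this change leaves the read-out level at this position. The same hydrogen gives a number 1.10 log units higher from compound 1 to compound 3 (beyond the scatter), which sets compound 1, with its 4-carbamoyl-2-(methylamino)phenyl, apart from the other two compounds. No measurement at hand accounts for this. Going by these compounds, whether a different group on this carbon, such as a dimethylamino, a methoxy or a carboxylic acid, would also leave the number level remains open.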